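The source may hold more compounds than are shown below. What is called first, only, known or untested is meant among the compounds shown, and "the series" means these compounds.

Working notes on the series in an ADME assay on L1210/0 cells (Mus musculus) for cytotoxicity, with a stated time of 48 h; a higher number here means a weaker inhibitor, a lower number a stronger inhibitor. Within the data shown here, compound 1 `CC(=O)OC(C)Cn1cnc2c(Cl)nc(I)nc21` gives 13000 nM in this assay, and it is the one compound of the three with a number rather than a limit. Compound 2 `N#Cc1cn([C@H]2C[C@H](O)[C@@H](CO)O2)c(=O)[nH]c1=O` returns only a limit in this assay, > 200000 nM. Compound 3 `CO/N=C/C1CC(n2cnc3c(N)ncnc32)C(O)C1O` also returns only a limit in this assay, > 200000 nM. Compound 2 therefore stands at the limit of > 200000 nM in this assay, at which 2 of the 3 values shown sit, with no number of its own; all that is known is that it is a weaker inhibitor than compound 1.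

Compound 4 `CC(C)(C)C#Cc1cn([C@H]2C[C@H](O)[C@@H](CO)O2)c(=O)[nH]c1=O` is not yet measured in this assay. It differs from compound 2 in one place: 3,3-dimethylbut-1-yn-1-yl in place of cyano on an aromatic carbon. Among the measured compounds shown here, no pair of measured compounds differing in one place is available, so there is no measured step of this kind to lean on, and the data give no measured property of the entering group.

The expectation is for a move toward stronger inhibition that goes beyond the scatter, from a limit to a number, with the step from compound 2 to compound 4 estimated as an at least 4.0-fold lower number from compound 2 to compound 4 (0.60 log units; beyond the scatter). Compound 4 is expected at about 50000 nM in this assay, within a wide range from 8000 nM to 200000 nM, and a further limit remains a real possibility.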

Compound 4, half-maximal inhibitory concentration: > 200000 nM
Compound 4 was reported as a limit (the forecaster's own chance of this, stated with the estimate: 35%); middle value at least 4.0-fold (0.60 log units) away from the limit.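

Compound 4, like compound 2, returns only a limit, so no step between the two can be read: the limit of > 200000 nM in this assay, at which 3 of the 4 values shown sit.

The compounds shown leave open whether 3,3-dimethylbut-1-yn-1-yl in place of cyano on an aromatic carbon shifts inhibition in this assay in either direction, with neither compound 2 nor compound 4 holding a number of its own.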